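The source may report more compounds than this note shows. Statements on the series, on what has been measured and on what is new or still open speak of the compounds shown alone.

Working notes on the series. For the measured compounds named here, in a functional assay on HepG2 cells (Homo sapiens) for inhibition, read by MTT assay, with a stated time of 24 h (a higher number here means a weaker inhibitor of growth, a lower number a stronger inhibitor of growth), compound 2 (`Cn1cc(-c2nc3ccccc3n2C(=O)c2ccccc2)c2cc(Br)ccc21`) gives 48100 nM and compound 3 (`COc1cccc(C(=O)n2c(-c3cn(C)c4ccc(Br)cc34)nc3ccccc32)c1`) gives 17800 nM as the second highest of the three numbers so far. Next in view is compound 4 (`COc1ccc(C(=O)n2c(-c3cn(C)c4ccc(Br)cc34)nc3ccccc32)cc1OC`), which differs from compound 3 by methoxy in place of hydrogen on an aromatic carbon, ortho to a methoxy group and para to a large group, so that 3-methoxyphenyl becomes 3,4-dimethoxyphenyl. Going by the values given here, the one measured step of the same kind is modest (a 2.7-fold lower number from compound 2 to compound 3 (0.43 log units; beyond the scatter)) and is the main guide here. Compound 1 (`COc1ccc2c(c1)c(-c1nc3ccccc3n1C(=O)c1ccc(OC)c(OC)c1)cn2C`) already carries the 3,4-dimethoxyphenyl group and gives 5100 nM in this assay but also differs from compound 3 elsewhere, so it supports the direction only loosely. Among the compounds with values here, no measured pair isolates this change alone. Another modest step toward a lower number is therefore expected (a 1.8-fold lower number from compound 3 to compound 4 (0.25 log units; within the scatter)). The estimate for compound 4 is 10000 nM within an expected range of 4500 nM to 22000 nM for this measurement.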

Compound 4, concentration for 50% growth inhibition: 9700 nM
Compound 4: the middle estimate sits 1.0-fold (0.01 log units) above what was measured; measured number inside the range.
By their numbers in this assay, from the lowest: compounds 1, 4 and 3 (each within the scatter of the next, the first and the last beyond it); then compound 2.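

In this assay, methoxy in place of hydrogen at this position, ortho to a methoxy group and para to a large group, gives a 1.8-fold lower number from compound 3 to compound 4 (0.26 log units; within the scatter) and so cannot be told apart from no change when read alone. The whole replacement, 3,4-dimethoxyphenyl in place of phenyl on a carbonyl carbon, gives a 5.0-fold lower number from compound 2 to compound 4 (0.70 log units; beyond the scatter) and lies beyond the scatter, so the series now holds a clear step for the two methoxy groups taken together. With 3,4-dimethoxyphenyl held constant, bromo in place of methoxy on an aromatic carbon gives a 1.9-fold higher number from compound 1 to compound 4 (0.28 log units; within the scatter) and does not separate the two groups on the core.

No measurement at hand bears on the reason for these numbers. Open, from the compounds shown here alone, is how an ethoxy group, a hydroxyl group or an amine at this position would read in this assay against the methoxy group of compound 4.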